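The compounds below may be only part of what the source reports. "The series", "measured", "known", "first", "only" and "open" are said of these compounds alone.

Of the compounds shown here, two have so far been measured in a functional assay on NCI-H322M cells (Homo sapiens) for cytotoxicity, read by sulforhodamine B assay, with a stated time of 48 h; on this read-out higher numbers stand for lower toxicity in this test and lower numbers for higher toxicity in this test. Compound 1 `Nc1nc(Cl)c2ncn(Cc3ccccc3CCl)c2n1` gives 69200 nM in this assay, and compound 2 `ClCc1cccc(Cn2cnc3nc(Cl)nc(Cl)c32)c1` gives 52500 nM. Compound 1 stands at the top of these two numbers, yet its value and that of compound 2 lie within the scatter of each other, so the pair reads alike, and both show only weak cytotoxicity. Compound 3 `ClCc1ccccc1Cn1cnc2c(Cl)ncnc21` has not yet been tested. It differs from compound 1 in a single place: hydrogen in place of amino on an aromatic carbon. Nothing measured here shows how this kind of change moves the read-out, and the two known values sit close together. The step of a 1.2-fold lower number from compound 1 to compound 3 (0.06 log units; within the scatter) is therefore expected to remain within the scatter, with no direction favoured. Compound 3 is estimated at 60000 nM, with a range from 25000 nM to 150000 nM.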

Compound 3, concentration lethal to 50% of the cells: 43700 nM
The estimate for compound 3 lay 1.4-fold (0.14 log units) above the measured number; low and high end bracket the measured number.
By their numbers in this assay, from the lowest: compounds 3, 2 and 1 (each within the scatter of the next).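

Hydrogen in place of amino on the aromatic carbon between two ring nitrogen atoms gives, in this assay, a 1.6-fold lower number from compound 1 to compound 3 (0.20 log units; within the scatter). Within the data shown here, this is the first comparison here of two compounds that differ in one place, and it shows that compound 1 and compound 3 read alike, so the amino group at this position is not required for the weak cytotoxicity seen in this test. No other data bear on this result.

Going by these compounds, whether a different group at this position, such as a methyl group, a hydroxyl group or a longer alkylamine, would shift the read-out beyond the scatter remains open. Also open, on these data alone, is what would follow from replacing the chloro group meta to this position with a methoxy group or an amine.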